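A few compounds are considered here, and "the series" means these few. Any claim that something is new, unique, unknown or untested is made for them only; others in the source may bear on it.

Working notes on the series. Compound 1 `Fc1ccc(-c2cn3ccnc3c(-c3ccc4ncn(C5CCCCC5)c4c3)n2)cc1` and compound 2 `Clc1ccc(-c2cn3ccnc3c(-c3ccc4ncn(C5CCCCC5)c4c3)n2)cc1` share one core and differ only in the halogen on the pendant phenyl. In a functional assay on SNB-19 cells (Homo sapiens) for inhibition, read by sulforhodamine B assay, with a stated time of 48 h, tested at 10 uM (on this read-out higher numbers stand for more inhibition at the one concentration tested (going by the name of the read-out) and lower numbers for less inhibition), compound 1 gives 14.2%. In this assay compound 2 gives 15.8%. The single step measured so far, a number 1.6 percentage points higher from compound 1 to compound 2 (within the scatter), is within the scatter, so on the numbers shown compound 2 stands alongside compound 1 with nothing to separate the two.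

Compound 3 `FC(F)(F)c1cccc(-c2cn3ccnc3c(-c3ccc4ncn(C5CCCCC5)c4c3)n2)c1` is the next member and has not yet been measured. The change from compound 2 is 3-(trifluoromethyl)phenyl in place of 4-chlorophenyl on an aromatic carbon. Within the data shown here, only the step from compound 1 to compound 2 bears on it, and that step was small; it concerned a halogen exchange on the same phenyl, whereas the present change moves to a different group at a different place on that phenyl, so its guidance is limited. Nothing in the measured data points to a step beyond the scatter in either direction, and the expected step of a number 0.8 percentage points lower from compound 2 to compound 3 (within the scatter) is therefore set near zero. For compound 3 the estimate in this assay is 15%, with a range from 3% to 32%.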

Compound 3, a percentage reported as inhibition, at one concentration (the size of the read-out at that concentration, not a potency): 2.24%
For compound 3 the middle estimate is 12.8 percentage points above the measured one; the whole stated range lies above it.
By their numbers in this assay, from the lowest: compound 3; then compounds 1 and 2 (each within the scatter of the next).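

In this assay, among these compounds, the substituent on the pendant phenyl now proves able to shift the read-out beyond the scatter: the data show a number 13.6 percentage points lower from compound 2 to compound 3 (beyond the scatter) and also a number 12 percentage points lower from compound 1 to compound 3 (beyond the scatter) in the same direction, whereas the exchange of halogen alone gave no separable step. The drop therefore appears from both 4-chlorophenyl and 4-fluorophenyl when 3-(trifluoromethyl)phenyl enters at the same aromatic carbon of the shared core, so this change matters here in a way that the halogen exchange did not. No measurement available here bears on the reason for this step.

The change alters both the group and its place on the phenyl, so the compounds shown cannot tell which of the two goes with the lower number; 4-(trifluoromethyl)phenyl and 3-chlorophenyl would separate them. Also open, going by these compounds, is how the read-out responds at this aromatic carbon to unsubstituted phenyl, or to a phenyl carrying an amine or a carboxylic acid, and whether any such group gives more inhibition than compound 1 and compound 2.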